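The source may report more compounds than this note shows. Statements on the series, on what has been measured and on what is new or still open speak of the compounds shown alone.

In a functional assay (aorta) with Oryctolagus cuniculus as the target (a lower number here means tighter binding, a higher number weaker binding), compound 1 `COC(=O)c1ccc(OCCCN2CCC(C(c3ccc(F)cc3)c3ccc(F)cc3)CC2)c(OC)c1` gives 1.26 nM and compound 2 `COc1cc(C#N)ccc1OCCCN1CCC(C(c2ccc(F)cc2)c2ccc(F)cc2)CC1` gives 2 nM while compound 3 `COc1cc(OCCCN2CCC(C(c3ccc(F)cc3)c3ccc(F)cc3)CC2)ccc1C(C)=O` gives 3.16 nM on the same scale. Two steps fix the place of compound 3: a 1.6-fold higher number from compound 2 to compound 3 (0.20 log units; within the scatter) lies within the scatter, and a 2.5-fold higher number from compound 1 to compound 3 (0.40 log units; beyond the scatter) lies modestly beyond it. Compound 4 `Fc1ccc(OCCCN2CCC(C(c3ccc(F)cc3)c3ccc(F)cc3)CC2)cc1` has 4-fluorophenyl in place of 4-acetyl-3-methoxyphenyl on an oxygen on a saturated carbon. Changes on that same oxygen have stayed small, as a 2.5-fold higher number from compound 1 to compound 3 (0.40 log units; beyond the scatter) shows, although no measured compound carries 4-fluorophenyl. No step beyond the scatter is therefore expected in this assay and the estimated change is small (a 1.3-fold higher number from compound 3 to compound 4 (0.10 log units; within the scatter)). For compound 4 the estimated value is 4 nM with an expected range from 1.2 nM to 14 nM for now.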

Compound 4, dissociation constant: 1.26 nM
Compound 4: the middle estimate sits 3.2-fold (0.50 log units) above what was measured; the range from low to high includes it.
By their numbers in this assay, from the lowest: compounds 1, 4, 2 and 3 (each within the scatter of the next, the first and the last beyond it).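

In this assay, the plain 4-fluorophenyl group on this oxygen gives up nothing to the more heavily substituted rings. Against the acetyl compound there is a modest step beyond the scatter (a 2.5-fold lower number from compound 3 to compound 4 (0.40 log units; beyond the scatter)), while the nitrile and ester compounds stay within it (a 1.6-fold lower number from compound 2 to compound 4 (0.20 log units; within the scatter); no change at the digits printed from compound 1 to compound 4 (within the scatter)), so among these compounds neither a methoxy group nor a carbonyl group is needed for a low number. Nothing measured here explains this result. Still open, as far as these compounds go, is how a phenyl ring carrying an amine or a carboxylic acid would read on this oxygen.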